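A few compounds are considered here, and "the series" means these few. Any claim that something is new, unique, unknown or untested is made for them only; others in the source may bear on it.

Within the shared core of compound 3 `CN[C@H](CC(C)C)Cn1c(=O)c(-c2cccc(OC)c2F)c(C)n(Cc2c(F)cccc2F)c1=O`, variation at the saturated chain carbon bound to an aromatic nitrogen dominates the series. In an assay on HEK293 cells for binding affinity to Gonadotropin-releasing hormone receptor (Homo sapiens), read by radioligand binding (on this read-out higher numbers stand for weaker inhibition and lower numbers for stronger inhibition), compound 3 gives 1.2 nM, the lowest number of the three; compound 1 `COc1cccc(-c2c(C)n(Cc3c(F)cccc3F)c(=O)n(C[C@H](C)NCc3ccccc3)c2=O)c1F` gives 51 nM and compound 2 `COc1cccc(-c2c(C)n(Cc3c(F)cccc3F)c(=O)n(C[C@@H](N)CCc3ccccc3)c2=O)c1F` gives 965 nM. The relevant steps were a 43-fold lower number from compound 1 to compound 3 (1.63 log units; beyond the scatter) and an 800-fold lower number from compound 2 to compound 3 (2.91 log units; beyond the scatter), so this position moves the read-out over a wide span. Going by the values given here, compound 4 `COc1cccc(-c2c(C)n(Cc3c(F)cccc3F)c(=O)n(C[C@@H](C3CCCCC3)N(C)C)c2=O)c1F` carries cyclohexyl(dimethylamino)methyl in place of 3-methyl-1-(methylamino)butyl on a saturated chain carbon bound to an aromatic nitrogen; a tertiary amine and a ring at this position have no measured precedent, so the step in this assay is uncertain in both sign and size. A moderate loss relative to compound 3 is expected, an 8.3-fold higher number from compound 3 to compound 4 (0.92 log units; beyond the scatter). Compound 4 is estimated at 10 nM, range 2 nM to 60 nM.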

Compound 4, inhibition constant: 4.1 nM
Compound 4: middle estimate off by 2.4-fold (0.39 log units), on the high side; the measured number falls inside the stated range.
By their numbers in this assay, from the lowest: compound 3; then compound 4; then compound 1; then compound 2.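

The position accepts a tertiary amine with 0 hydrogen-bond donors and a six-membered carbon ring: cyclohexyl(dimethylamino)methyl gives only a modest loss against 3-methyl-1-(methylamino)butyl (a 3.4-fold higher number from compound 3 to compound 4 (0.53 log units; beyond the scatter)). The same group stays well ahead of both phenyl-bearing groups, 1-(benzylamino)ethyl (a 12-fold lower number from compound 1 to compound 4 (1.09 log units; beyond the scatter)) and 1-amino-3-phenylpropyl (a 240-fold lower number from compound 2 to compound 4 (2.37 log units; beyond the scatter)). No evidence is available to explain the size of these steps.

From the compounds shown here alone, the ring and the second methyl on nitrogen change together, so their separate contributions remain open. Cyclohexyl(methylamino)methyl would isolate the ring from the nitrogen change.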